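Cyclohexyl-pyrazole tetrazolylacetamides: aryl swap on the tetrazole

The compounds below may be only part of what the source reports. "The series", "measured", "known", "first", "only" and "open" are said of these compounds alone.

Measured so far in an assay on HEK293 cells for activation of Kir3.1/Kir3.2 (Homo sapiens), read by thallium flux; a lower number here means that less compound is needed, a higher number that more compound is needed for the effect:
- Compound 1 `Cc1cc(NC(=O)Cn2nnc(-c3ccccc3)n2)n(C2CCC(C)(C)CC2)n1`; for compound 1 the value is a limit of the assay, > 221 nM.
- Compound 2 `Cc1cc(NC(=O)Cn2nnc(-c3ccc(F)cc3)n2)n(C2CCCCC2)n1`; compound 2 gives 180 nM.
- Compound 3 `Cc1cc(NC(=O)Cn2nnc(-c3cccc(F)n3)n2)n(C2CCCCC2)n1`; for compound 3 the value is a limit of the assay, > 3000 nM.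

Compound 3 thus stands at the weak end of the three numbers, and its value is a limit only (the limit of > 3000 nM in this assay, at which 1 of the 3 values shown sits). Compound 4 `Cc1cc(NC(=O)Cn2nnc(-c3cccc(C#N)c3)n2)n(C2CCCCC2)n1` differs from it in one place: 3-cyanophenyl in place of 6-fluoropyridin-2-yl on an aromatic carbon.

Going by the values given here, the one measured step that bears on this is an at least 16-fold higher number from compound 2 to compound 3 (1.22 log units; beyond the scatter), where the six-membered ring of carbon only gave way to the ring with one hetero atom. The change to compound 4 runs the other way, back to a ring of carbon only, with a nitrile in place of the fluorine. Compound 1, with a plain phenyl on a different cyclohexyl, sits at a limit (the limit of > 221 nM in this assay, at which 1 of the 3 values shown sits), so the carbon-only aryls cluster near the value of compound 2.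

A step of roughly the same size in the opposite direction is therefore expected: an at least 7.5-fold lower number from compound 3 to compound 4 (0.87 log units; beyond the scatter). Compound 4 is estimated at 400 nM, within 120 nM to 1500 nM.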

Compound 4, half-maximal effective concentration: 183 nM
Compound 4: middle estimate off by 2.2-fold (0.34 log units), on the high side; the range from low to high includes it.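

In this assay, replacing 6-fluoropyridin-2-yl with 3-cyanophenyl gives an at least 16-fold lower number from compound 3 to compound 4 (1.21 log units; beyond the scatter), so the loss seen with the ring holding a hetero atom does not extend to every new group at this position on the tetrazole. Replacing 4-fluorophenyl with 3-cyanophenyl gives a 1.0-fold higher number from compound 2 to compound 4 (0.01 log units; within the scatter), so these two rings of carbon only, with different groups at different ring positions, cannot be told apart here, while 6-fluoropyridin-2-yl is the one aryl among the three that goes against them. The size of the first step remains open-ended, as the value of compound 3 is only a limit of the assay: the limit of > 3000 nM in this assay, at which 1 of the 4 values shown sits.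

Going by these compounds, it remains open whether the ring nitrogen alone carries the loss, which a plain pyridin-2-yl or a 3-cyanopyridine-type ring would test. Also open, on these data alone, is how a phenyl ring bearing an amine or a carboxylic acid would read out in this assay.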